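This account rests on a few compounds, and the source may have more. Where it says the series, first, only, none or still open, it means among the compounds named here.

Of the compounds shown here, three sharing one core have so far been measured in a physicochemical assay for solubility, in phosphate buffer, with a stated time of 18 h; on this read-out lower numbers stand for lower solubility and higher numbers for higher solubility. Compound 1, `CC(C)(C)c1nc(CCCCCC#N)c2c(N)c(C#N)c(N)nc2n1`, gives 6000 nM. Compound 2, `CC(C)(C)c1nc(C2CCCC2)c2c(N)c(C#N)c(N)nc2n1`, gives only a limit of the assay, < 1000 nM. Compound 3, `CC(C)(C)c1nc(-c2ccsc2)c2c(N)c(C#N)c(N)nc2n1`, gives 40000 nM, which is the highest of the two numbers shown; the change a 6.7-fold higher number from compound 1 to compound 3 (0.82 log units; beyond the scatter) is modest, and the change an at least 40-fold higher number from compound 2 to compound 3 (1.60 log units; beyond the scatter) is large. Compound 4, `CC(C)(C)c1nc(-c2ncc[nH]2)c2c(N)c(C#N)c(N)nc2n1`, has not yet been measured and differs from compound 3 in one place: 1H-imidazol-2-yl in place of thiophen-3-yl on an aromatic carbon. Both measured steps swap the group on this same aromatic carbon, and both end at compound 3 as the higher number, so this position clearly governs the read-out. Neither of them, however, brings in a hydrogen-bond donor, as the 1H-imidazol-2-yl does, so the measured steps set no direct size for this change. A small step upward, a 2.0-fold higher number from compound 3 to compound 4 (0.30 log units; within the scatter), is expected, not clearly beyond the scatter. Compound 4 is therefore estimated at 80000 nM, within a range from 25000 nM to 250000 nM.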

Compound 4, solubility: < 1000 nM
Compound 4: no number, only a limit; the forecaster's own chance of this, stated with the estimate: 5%; middle value at least 80-fold (1.90 log units) from the limit.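

In this assay, replacing thiophen-3-yl with 1H-imidazol-2-yl brings an at least 40-fold lower number from compound 3 to compound 4 (1.60 log units; beyond the scatter), so two five-membered aromatic rings with the same heavy-atom count and no net charge are far from interchangeable on this aromatic carbon. The same group also gives an at least 6.0-fold lower number from compound 1 to compound 4 (0.77 log units; beyond the scatter), which shows that an aromatic ring here does not by itself go with the higher number, as compound 3 alone might have suggested. Compound 4 gives < 1000 nM, which is a limit of the assay and not a number.

The step between compound 2 and compound 4 cannot be read, since both stop at the same limit: the limit of < 1000 nM in this assay, at which 2 of the 4 values shown sit A 1-methyl-1H-imidazol-2-yl group at this place would help show whether the fall goes with the hydrogen-bond donor or with the second ring nitrogen.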